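Series notes: 4-aminoindazole-1-carboxamides, ring substituent at the five-position

The source may hold more compounds than are shown below. What is called first, only, known or untested is meant among the compounds shown, and "the series" means these compounds.

Measured so far:
Compound 1, `Nc1nn(C(=O)Nc2ccc(Cc3ccccc3)cc2)c2ccccc12`: 2390 nM
Compound 2, `Nc1nn(C(=O)Nc2ccc(Cc3ccccc3)cc2)c2ccc(Cl)cc12`: 1150 nM

Both compounds share one core and differ only on the fused benzene ring. In a functional assay on HT-29 cells (Homo sapiens) for antiproliferative activity, read by sulforhodamine B assay, with a stated time of 48 h (on this read-out higher numbers stand for weaker inhibition of growth and lower numbers for stronger inhibition of growth), compound 1 gives 2390 nM, while compound 2 gives 1150 nM. Going by the values given here, the single step between them, a 2.1-fold lower number from compound 1 to compound 2 (0.32 log units; beyond the scatter), is modest but beyond the scatter, so compound 2 stands as the lower of the two numbers measured to date, with compound 1 as its only neighbour.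

Compound 3, `Nc1ccc2c(c1)c(N)nn2C(=O)Nc1ccc(Cc2ccccc2)cc1`, has not yet been measured. It differs from compound 2 by amino in place of chloro on an aromatic carbon. Among the compounds with values here, only one measured step concerns this ring position, and it describes hydrogen to chloro, not chloro to amino; no step tells what an amino group at this place does. The expectation is therefore loose: the number for compound 3 is expected to lie between the values seen, with a wide range. The estimated step of a 1.7-fold higher number from compound 2 to compound 3 (0.24 log units; within the scatter) is taken to be a small move back toward compound 1. The estimate for compound 3 is 2000 nM, with a range from 600 nM to 6500 nM.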

Compound 3, concentration for 50% growth inhibition: 4510 nM
Compound 3: the middle estimate sits 2.3-fold (0.35 log units) below what was measured; the measured number falls inside the stated range.
By their numbers in this assay, from the lowest: compound 2; then compounds 1 and 3 (each within the scatter of the next).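

In this assay, the response at this aromatic carbon now depends on which group is placed there: amino in place of chloro gives a 3.9-fold higher number from compound 2 to compound 3 (0.59 log units; beyond the scatter) and so does not share the lower number seen with chloro. Amino in place of hydrogen gives a 1.9-fold higher number from compound 1 to compound 3 (0.28 log units; within the scatter) and cannot be told apart from hydrogen, leaving compound 2 as the only compound of the three that stands apart from the others. Nothing available here accounts for the difference between chloro and amino at this carbon.

As far as these compounds go, it remains open whether the lower number goes with chloro alone or also with bromo, methyl or methoxy on this aromatic carbon. From the compounds shown here alone, it is equally open whether an acetamide at this place would stay level with compound 1 or come close to compound 2.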